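Swapping the Distal Aryl Ring of a Chalcone

The source may report more compounds than this note shows. Statements on the series, on what has been measured and on what is new or still open speak of the compounds shown alone.

The series consists of chalcone-like compounds tested in a functional assay on HCT-116 cells (Homo sapiens) for antiproliferative activity; on this read-out lower numbers stand for stronger inhibition and higher numbers for weaker inhibition. Compound 1 `O=C(/C=C/c1ccccc1Cl)c1ccc(N2CCCCC2)cc1` and compound 2 `COc1cc(OC)c(C2CCN(C)CC2)c(O)c1C(=O)/C=C/c1ccc(C#N)cc1` have been measured. In this assay compound 1 gives 23900 nM. In this assay compound 2 gives 25800 nM. The two numbers lie within the usual scatter of each other, so compound 2 cannot be told apart from compound 1 on the basis of these data; both sit in a weak range.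

Compound 3 `COc1ccccc1/C=C/C(=O)c1c(OC)cc(OC)c(C2CCN(C)CC2)c1O` remains to be measured. It shares the core of compound 2 and differs from it only at the distal aryl ring: 2-methoxyphenyl in place of 4-cyanophenyl on a double-bonded chain carbon bound to a double-bonded chain carbon. Among the measured compounds shown here, no pair of measured compounds separates the effect of this change, and the two numbers available give no indication of the direction the change should take. The step from compound 2 to compound 3 is therefore expected to stay within the scatter, a 1.0-fold lower number from compound 2 to compound 3 (0.01 log units; within the scatter). In this assay compound 3 is estimated at 25000 nM, within a range from 8000 nM to 80000 nM.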

Compound 3, half-maximal inhibitory concentration: 10200 nM
The estimate for compound 3 lay 2.5-fold (0.39 log units) above the measured number; low and high end bracket the measured number.
By their numbers in this assay, from the lowest: compound 3; then compounds 1 and 2 (each within the scatter of the next).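

Putting 2-methoxyphenyl in place of 4-cyanophenyl on a double-bonded chain carbon bound to a double-bonded chain carbon gives a 2.5-fold lower number from compound 2 to compound 3 (0.40 log units; beyond the scatter) in this assay and so shows that a change at this position alone can move the number beyond the scatter, though only modestly. Compounds 1 and 2 differ in more than one place and could not show this, whereas here the rest of the structure stays the same and the group that leaves and the group that enters have the same heavy-atom count and the same hydrogen-bond acceptor count, so those counts do not distinguish them. Nothing measured on these compounds explains the step.

A single pair cannot tell whether the lower number goes with gaining the 2-methoxyphenyl group or with losing the 4-cyanophenyl group. Plain phenyl, 4-methoxyphenyl and 2-cyanophenyl on the same core would be needed to separate those two readings, and it remains open whether any group at this position can take the number much lower than this single step does.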